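The compounds below may be only part of what the source reports. "The series", "measured", "known", "first", "only" and "open" are said of these compounds alone.

For the measured compounds named here, compound 2 `COc1cc(-c2nn(-c3cccc(NC(=O)c4ccc(Cl)c(C(F)(F)F)c4)c3)cc2-c2ccncc2)ccc1Cl` gives 2060 nM in a functional assay on KM12 cells (Homo sapiens) for inhibition, read by sulforhodamine B assay, with a stated time of 48 h (a lower number here means a stronger inhibitor, a higher number a weaker inhibitor), the highest of the three numbers so far. Compound 1 `COc1cc(-c2nn(-c3cccc(NC(=O)Nc4cccc(C(F)(F)F)c4)c3)cc2-c2ccncc2)ccc1Cl` gives 570 nM in this assay, and compound 3 `O=C(Nc1cccc(-n2cc(-c3ccncc3)c(-c3ccc(Cl)c(O)c3)n2)c1)Nc1cc(C(F)(F)F)cc(C(F)(F)F)c1` gives 510 nM. Compound 1 and compound 3 differ from each other in more than one place, so their two values are simply set side by side. Going by the values given here, the one single-point step measured is a 3.6-fold higher number from compound 1 to compound 2 (0.56 log units; beyond the scatter), a change of the group on the carbonyl carbon.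

Compound 4 `COc1cc(-c2nn(-c3cccc(NC(=O)c4ccccc4)c3)cc2-c2ccncc2)ccc1Cl` is now to be measured in this assay. It differs from compound 2 by phenyl in place of 4-chloro-3-(trifluoromethyl)phenyl on a carbonyl carbon. Among the compounds with values here, no measured pair shows this kind of change; the step from compound 1 to compound 2 exchanges the whole group on the carbonyl carbon, whereas here the amide is kept and only the substituents on its aryl group are removed. Within the data shown here, the only guide is that compound 2 sits at the weak end, and that the one known step on this carbonyl carbon was of modest size. A step of modest size is therefore expected, with weaker inhibition more likely than stronger, so that compound 4 is expected to come out around 3000 nM, within 1000 nM to 9000 nM, an expected step of a 1.5-fold higher number from compound 2 to compound 4 (0.16 log units; within the scatter).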

Compound 4, half-maximal inhibitory concentration: 560 nM
Beside the measured number, compound 4's estimate is 5.4-fold (0.73 log units) above it, outside the stated range (below it).
By their numbers in this assay, from the lowest: compounds 3, 4 and 1 (each within the scatter of the next); then compound 2.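

In this assay, cutting the 4-chloro-3-(trifluoromethyl)phenyl group back to plain phenyl on the carbonyl carbon gives a 3.7-fold lower number from compound 2 to compound 4 (0.57 log units; beyond the scatter) and so shows that the amide of compound 2 can be kept while its number falls, a change the earlier step, which exchanged the whole group on that carbon, could not separate out. The urea of compound 1 and the plain benzamide of compound 4 stand level, with a 1.0-fold lower number from compound 1 to compound 4 (0.01 log units; within the scatter) as their step, so among these three compounds the high number goes with the 4-chloro-3-(trifluoromethyl)phenyl group and not with the amide as such. No measurement at hand says why the substituted aryl group goes with the weaker inhibition.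

The compounds shown carry the chlorine and the trifluoromethyl on the amide's aryl group either together or not at all, so it stays open whether one of them alone goes with the higher number. Also open, going by these compounds, is how the number would respond to an amine or a carboxylic acid on that phenyl, or to a longer chain in its place on the carbonyl carbon.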